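Replacing 2,6-difluorophenyl with pyridin-3-yl: a solubility estimate

This account rests on a few compounds, and the source may have more. Where it says the series, first, only, none or still open, it means among the compounds named here.

Measured in a physicochemical assay for solubility, measured as kinetic solubility, with a stated time of 1 h, at pH 7.4; a lower number here means a less soluble compound, a higher number a more soluble compound:
- Compound 1 `O=C(Nc1nc(-c2ccc(Cl)c(Cl)c2)cs1)C1CC1`: 3000 nM
- Compound 2 `O=C(Nc1nc(-c2ccc(Cl)c(Cl)c2)cs1)c1c(F)cccc1F`: 5000 nM
- Compound 3 `Cn1ncc([N+](=O)[O-])c1C(=O)Nc1nc(-c2ccc(Cl)c(Cl)c2)cs1`: < 1000 nM (a limit of the assay, not a number)

Compound 2 sits level with compound 1 in this assay: the measured step is a 1.7-fold higher number from compound 1 to compound 2 (0.22 log units; within the scatter). Compound 4 `O=C(Nc1nc(-c2ccc(Cl)c(Cl)c2)cs1)c1cccnc1`, not yet measured, carries pyridin-3-yl in place of 2,6-difluorophenyl on a carbonyl carbon. For the measured compounds named here, the change from cyclopropyl to 2,6-difluorophenyl is the only step at this carbonyl carbon with a number at both ends. Going by the values given here, it stayed within the scatter, and no measured compound carries pyridin-3-yl. A change beyond the scatter is therefore not expected, in either direction. The expected step is a 1.3-fold lower number from compound 2 to compound 4 (0.10 log units; within the scatter). For compound 4 the estimated value is 4000 nM, with an expected range from 1500 nM to 12000 nM.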

Compound 4, solubility: 20000 nM
Beside the measured number, compound 4's estimate is 5.0-fold (0.70 log units) below it, and the stated range ends below it.
By their numbers in this assay, from the lowest: compounds 1 and 2 (each within the scatter of the next); then compound 4. At a limit, below all of these: compound 3.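

In this assay, this carbonyl carbon proves to be a place where the group can matter, with a 4.0-fold higher number from compound 2 to compound 4 (0.60 log units; beyond the scatter). Pyridin-3-yl also stands apart from cyclopropyl, with a 6.7-fold higher number from compound 1 to compound 4 (0.82 log units; beyond the scatter), whereas the earlier step between the other two groups stayed within the scatter. Nothing given here accounts for this rise.

The compounds shown do not separate the effect of the entering ring nitrogen from that of the departing fluorines; a plain phenyl group on this carbonyl carbon would do so. They also leave open whether pyridin-4-yl would behave like pyridin-3-yl.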